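A few compounds are considered here, and "the series" means these few. Any claim that something is new, unique, unknown or untested is made for them only; others in the source may bear on it.

Compounds measured so far:
compound 1 `C[C@@H](O[C@H]1CN2C(=O)C=C(c3ccncc3)CC2[C@@H]1c1ccc(F)cc1)c1cc(C(F)(F)F)cc(C(F)(F)F)c1` – 8.1 nM
compound 2 `C[C@@H](O[C@H]1CN2C(=O)C=C(c3cnn(C)c3)CC2[C@@H]1c1ccc(F)cc1)c1cc(C(F)(F)F)cc(C(F)(F)F)c1` – 5.4 nM

In an assay on CHO cells for displacement of a labelled ligand from Substance-P receptor (Homo sapiens), in the presence of a further agent that is not named here (a lower number here means a stronger inhibitor, a higher number a weaker inhibitor), compound 2 gives 5.4 nM, the lowest of the two numbers; its nearest neighbour is compound 1 with 8.1 nM, and the step of a 1.5-fold lower number from compound 1 to compound 2 (0.18 log units; within the scatter) lies within the scatter. Compound 3 `C[C@@H](O[C@H]1CN2C(=O)C=C(C3CCOCC3)CC2[C@@H]1c1ccc(F)cc1)c1cc(C(F)(F)F)cc(C(F)(F)F)c1` has not yet been measured; it differs from compound 2 by oxan-4-yl in place of 1-methyl-1H-pyrazol-4-yl on a double-bonded ring carbon. Among the measured compounds shown here, the only measured step that bears on this position, a 1.5-fold lower number from compound 1 to compound 2 (0.18 log units; within the scatter), swapped one aromatic ring for another, so the data give no direct guide to a non-aromatic ring at this place. For the measured compounds named here, with no measured precedent, a modest move to a higher number is expected as the most likely outcome, but the uncertainty is wide. For compound 3 the estimate in this assay is 11 nM, with a range from 3 nM to 40 nM. The expected step from compound 2 to compound 3 is a 2.0-fold higher number from compound 2 to compound 3 (0.31 log units; beyond the scatter).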

Compound 3, half-maximal inhibitory concentration: 3.2 nM
Compound 3: middle estimate off by 3.4-fold (0.54 log units), on the high side, and the stated range covers the measured number.
By their numbers in this assay, from the lowest: compounds 3, 2 and 1 (each within the scatter of the next, the first and the last beyond it).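

In this assay, this position on the double-bonded ring carbon does not depend on an aromatic ring: oxan-4-yl, a six-membered non-aromatic ring, stands level with 1-methyl-1H-pyrazol-4-yl (a 1.7-fold lower number from compound 2 to compound 3 (0.23 log units; within the scatter)). Replacing pyridin-4-yl with the same group gives the only step among these three compounds that passes the scatter, and it is a modest one (a 2.5-fold lower number from compound 1 to compound 3 (0.40 log units; beyond the scatter)). Nothing available here explains why the non-aromatic ring is accepted at this place.

The compounds shown do not tell whether the ring oxygen of oxan-4-yl matters, which a plain cyclohexyl ring would test. They also leave open how this position would respond to a ring amine such as piperidin-4-yl, or to an open chain such as n-butyl in place of a ring.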